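Heteroaryl swap on the bicyclic amine: cytotoxicity outlook

A few compounds are considered here, and "the series" means these few. Any claim that something is new, unique, unknown or untested is made for them only; others in the source may bear on it.

Compound 1 `Cc1ccc(CN[C@@H]2C[C@H]3C[C@@H]([C@H]2C)C3(C)C)s1` gives 780 nM in an ADME assay on MDCK cells (Canis lupus familiaris) for cytotoxicity, read by microscopy, with a stated time of 48 h; a lower number here means that less compound is tolerated, a higher number that more compound is tolerated.
Compound 2 `C[C@H]1[C@H](NCc2cc(Br)cs2)C[C@H]2C[C@@H]1C2(C)C` gives 6250 nM in this assay.
Compound 3 `C[C@H]1[C@H](NCc2ccoc2)C[C@H]2C[C@@H]1C2(C)C` gives > 100000 nM in this assay; this is a limit of the assay and not a number.

Compound 3 therefore stands at the limit of > 100000 nM in this assay, at which 1 of the 3 values shown sits, and is the most tolerated of the three, its steps from the others both lying beyond the scatter. The move to compound 4 `C[C@H]1[C@H](NCc2nccs2)C[C@H]2C[C@@H]1C2(C)C` is 1,3-thiazol-2-yl in place of furan-3-yl on a saturated chain carbon bound to an amine nitrogen. Going by the values given here, no measured step carries this exact change. The nearest steps are the ones into compound 3: an at least 120-fold higher number from compound 1 to compound 3 (2.10 log units; beyond the scatter) and an at least 16-fold higher number from compound 2 to compound 3 (1.20 log units; beyond the scatter), and among the two thiophene analogues an 8.0-fold higher number from compound 1 to compound 2 (0.90 log units; beyond the scatter). All three show that the five-membered ring attached to the saturated chain carbon bound to an amine nitrogen shifts the readout of this assay strongly, and that the furan-3-yl analogue lies at the tolerated end. Among the compounds with values here, with no thiazole precedent, the direction for compound 4 is uncertain, but a return towards the numbers of the thiophene analogues is expected rather than a further rise. Compound 4 is estimated at 25000 nM, between 4000 nM and 100000 nM, which means an expected step of an at least 4.0-fold lower number from compound 3 to compound 4 (0.60 log units; beyond the scatter).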

Compound 4, minimum cytotoxic concentration: > 100000 nM
Compound 4 gave a limit, no number; the forecaster's own chance of this, stated with the estimate: 35%; at least 4.0-fold (0.60 log units) between middle value and limit.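

Replacing either thiophene with 1,3-thiazol-2-yl on a saturated chain carbon bound to an amine nitrogen gives a large step, an at least 16-fold higher number from compound 2 to compound 4 (1.20 log units; beyond the scatter) and an at least 120-fold higher number from compound 1 to compound 4 (2.10 log units; beyond the scatter) and so a sulfur atom in the five-membered ring does not by itself go with the lower numbers of compound 1 and compound 2. The step between compound 3 and compound 4 cannot be read, since both values are limits, so these two compounds cannot be ordered. In this assay compound 4 gives a limit of the assay and not a number, so the top of the range is no longer held by furan-3-yl alone: the limit of > 100000 nM in this assay, at which 2 of the 4 values shown sit.

From the compounds shown here alone, whether a methyl or a bromo on the 1,3-thiazol-2-yl ring would bring the number back down remains open. So does whether a six-membered ring such as phenyl or pyridin-3-yl at this place would stay at the limit.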